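Aryl Replacing Amino on a Purine-Indanol Scaffold

The compounds below may be only part of what the source reports. "The series", "measured", "known", "first", "only" and "open" are said of these compounds alone.

Measured compounds:
compound 1 `Nc1ncnc2c1ncn2C[C@@H]1C[C@H](O)c2ccccc21` — > 200000 nM
compound 2 `OC[C@H]1C[C@@H](Cn2cnc3c(-c4ccccc4)ncnc32)c2ccccc21` — 28100 nM

The study follows a single change on the core of compound 1 `Nc1ncnc2c1ncn2C[C@@H]1C[C@H](O)c2ccccc21`, tested for cytotoxicity in an ADME assay on L1210/0 cells (Mus musculus) for cytotoxicity, with a stated time of 48 h; on this read-out higher numbers stand for weaker inhibition and lower numbers for stronger inhibition. For compound 1 only a limit is reported, > 200000 nM, which is a limit of the assay and not a number. Compound 2 `OC[C@H]1C[C@@H](Cn2cnc3c(-c4ccccc4)ncnc32)c2ccccc21`, which carries a different alcohol-bearing linker and a phenyl on the core, gives 28100 nM in this assay. The one limit that appears, (the limit of > 200000 nM in this assay, at which 1 of the 2 values shown sits), leaves the position of compound 1 open beyond the fact that it shows no measurable inhibition within the tested range.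

Compound 3 `COc1ccccc1-c1ncnc2c1ncn2C[C@@H]1C[C@H](O)c2ccccc21` differs from compound 1 in one place: 2-methoxyphenyl in place of amino on an aromatic carbon. For the measured compounds named here, no step between measured compounds isolates this change, yet compound 2 shows that an aryl group on the core is compatible with measurable cytotoxicity. Compound 3 is therefore expected to gain potency relative to compound 1, a step of an at least 4.0-fold lower number from compound 1 to compound 3 (0.60 log units; beyond the scatter) that is estimated to lie beyond the usual scatter. The estimated value for compound 3 is 50000 nM, with a range from 10000 nM to 200000 nM.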

Compound 3, half-maximal inhibitory concentration: > 200000 nM
Compound 3: a limit, no number; the forecaster's own chance of this, stated with the estimate: 35%; at least 4.0-fold (0.60 log units) between middle value and limit.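

In this assay compound 3 gives > 200000 nM as a limit of the assay and not a number. For the compounds shown here, compound 1 also carries only a limit, so no step between compound 1 and compound 3 can be read: the limit of > 200000 nM in this assay, at which 2 of the 3 values shown sit. The compounds shown leave open how far 2-methoxyphenyl in place of amino shifts this read-out, if at all.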